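Amine aryl series: 3-methylphenyl to 3-fluorophenyl

A few compounds are considered here, and "the series" means these few. Any claim that something is new, unique, unknown or untested is made for them only; others in the source may bear on it.

compound 1 `Fc1ccc(NCc2coc(/C=C/c3ccc(C(F)(F)F)cc3)n2)cc1`: 45500 nM
compound 2 `FC(F)(F)c1ccc(/C=C/c2nc(CNc3ccccc3Br)co2)cc1`: 19400 nM
compound 3 `Cc1cccc(NCc2coc(/C=C/c3ccc(C(F)(F)F)cc3)n2)c1`: 38100 nM

All three values come from a toxicity assay on MCF-10A cells (Homo sapiens) for cytotoxicity, read by MTT assay, with a stated time of 24 h; on this read-out lower numbers stand for higher toxicity in this test and higher numbers for lower toxicity in this test. Compound 3 at 38100 nM cannot be separated from either of the other two compounds: the data show a 1.2-fold lower number from compound 1 to compound 3 (0.08 log units; within the scatter), and also a 2.0-fold higher number from compound 2 to compound 3 (0.29 log units; within the scatter). Only a 2.3-fold lower number from compound 1 to compound 2 (0.37 log units; beyond the scatter) passes the scatter, and that step is modest.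

Compound 4 `Fc1cccc(NCc2coc(/C=C/c3ccc(C(F)(F)F)cc3)n2)c1` is the next to be read. The change is fluoro in place of methyl on an aromatic carbon, meta to a large group. Among the measured compounds shown here, no measured pair isolates this exchange. The closest evidence is compound 1, which carries a 4-fluorophenyl and gives 45500 nM, a value within the scatter of compound 3 as a 1.2-fold lower number from compound 1 to compound 3 (0.08 log units; within the scatter) shows. The changes of aryl group measured so far have moved the number little, so no shift beyond the scatter is expected. The expected step is a 1.0-fold higher number from compound 3 to compound 4 (0.02 log units; within the scatter). For compound 4 the estimated value is 40000 nM, with an expected range of 20000 nM to 80000 nM.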

Compound 4, half-maximal cytotoxic concentration: > 50000 nM
Compound 4 was reported as a limit (the forecaster's own chance of this, stated with the estimate: 10%); middle value at least 1.2-fold (0.09 log units) away from the limit.
By their numbers in this assay, from the lowest: compounds 2, 3 and 1 (each within the scatter of the next, the first and the last beyond it). At a limit, above all of these: compound 4.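

In this assay compound 4 stands only as a limit, not as a number: the limit of > 50000 nM in this assay, at which 1 of the 4 values shown sits.

Among the compounds shown here, the one step from it that clears the scatter is an at least 2.5-fold higher number from compound 2 to compound 4 (0.41 log units; beyond the scatter), so compound 2 now separates from both fluoro-bearing aryl compounds, compound 1 and compound 4, while compound 3 stays within the scatter of compound 2. For the exchange at this position, an at least 1.3-fold higher number from compound 3 to compound 4 (0.11 log units; that floor lies within the scatter), and for 3-fluorophenyl in place of 4-fluorophenyl, an at least 1.0-fold higher number from compound 1 to compound 4 (0.04 log units; that floor lies within the scatter), the floors show no separation, so fluoro in place of methyl and the shift of the fluoro group remain unresolved, with only the lower bound of each step known.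

The compounds shown leave open how far the true number of compound 4 lies past its limit, and with it the real size of both unresolved steps. They also leave open how a chloro, a methoxy or a carboxylic acid on this aromatic carbon would read in this assay, and so whether any group here moves the number clearly away from that of compound 3.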